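This account rests on a few compounds, and the source may have more. Where it says the series, first, only, none or still open, it means among the compounds named here.

Three compounds share one core and differ only in the group carried on the aromatic ring that sits next to the thiocarbamate nitrogen: compound 1 `Fc1cccc(NC(=S)OCCc2ccccn2)c1` carries fluoro, compound 2 `S=C(Nc1cccc(Cl)c1)OCCc1ccccn1` chloro, and compound 3 `O=[N+]([O-])c1cccc(NC(=S)OCCc2ccccn2)c1` nitro. In an ADME assay on MT4 cells (Homo sapiens) for cytotoxicity, read by MTT assay (a higher number here means that more compound is tolerated, a lower number that less compound is tolerated), compound 1 gives >= 100000 nM, which is a limit of the assay rather than a measured number, so compound 1 stands only at the top edge of the scale, as the limit of >= 100000 nM in this assay, at which 1 of the 3 values shown sits, records. Compound 2 gives 47000 nM in this assay. Compound 3 gives 100000 nM. The steps among these three are small: an at least 2.1-fold lower number from compound 1 to compound 2 (0.32 log units; beyond the scatter), a 2.1-fold higher number from compound 2 to compound 3 (0.33 log units; beyond the scatter), and a number no higher from compound 1 to compound 3 (the limit leaves the size open).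

Compound 4 `Fc1ccc(F)c(NC(=S)OCCc2ccccn2)c1` is not yet measured. It differs from compound 1 by fluoro in place of hydrogen on an aromatic carbon. Among the compounds with values here, none of the measured steps adds a second group; they only exchange one group for another, and even those exchanges move this assay by no more than a modest amount. A second fluoro is therefore expected to leave compound 4 close to compound 1, with a step of a number no higher from compound 1 to compound 4 (the limit leaves the size open) expected. Compound 4 is estimated at 100000 nM in this assay, within a range from 40000 nM to 200000 nM, and it may well again reach only the limit.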

Compound 4, half-maximal cytotoxic concentration: > 100000 nM
Compound 4: a limit, no number; the forecaster's own chance of this, stated with the estimate: 50%; the middle value sits exactly at the limit.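

Within the data shown here, compound 1 and compound 4 both give only a limit in this assay, not a number, so no step between them can be read. The compounds shown leave open whether fluoro in place of hydrogen on an aromatic carbon changes the tolerated concentration at all.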